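Dropping the Bromo from Compound 1: Half-Life Outlook

The compounds below may be only part of what the source reports. "The series", "measured", "known", "first", "only" and "open" are said of these compounds alone.

Compound 1 `O=C(NCc1ccccc1Br)N1C(=O)c2ccccc2S1(=O)=O` stands at the upper edge of what a physicochemical assay for pharmacokinetics (on this read-out higher numbers stand for a longer-lived compound and lower numbers for a shorter-lived compound), can report: in this assay compound 1 gives > 166 h, which is a limit of the measurement and not a number. Compound 2 `COc1cccc(CNC(=O)N2C(=O)c3ccccc3S2(=O)=O)c1` likewise gives > 166 h in this assay, again a limit. The step that the two limits leave unreadable from compound 1 to compound 2 therefore cannot be read for size, since (the limit of > 166 h in this assay, at which 2 of the 2 values shown sit). Compound 3 `O=C(NCc1ccccc1)N1C(=O)c2ccccc2S1(=O)=O` differs from compound 1 by hydrogen in place of bromo on an aromatic carbon. Among the compounds with values here, no measured step bears directly on this change, and the only measured step has both ends at the limit, so nothing among the measured compounds points to a shorter-lived result. The step of a number no higher from compound 1 to compound 3 (the limit leaves the size open) is expected to be none beyond the scatter. Compound 3 is estimated at 166 h, between 90 h and 330 h, most likely reported again only as a limit.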

Compound 3, half-life: > 166 h
Compound 3: a limit, no number (the forecaster's own chance of this, stated with the estimate: 75%); the middle value sits exactly at the limit.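

Within the data shown here, compound 3, like compound 1 and compound 2, returns only a limit in this assay, so no step among the three can be read: the limit of > 166 h in this assay, at which 3 of the 3 values shown sit. The compounds shown leave open how long each actually lasts in this assay, and whether bromo, methoxy or hydrogen on the aromatic carbon changes that at all.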